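The compounds below may be only part of what the source reports. "The series", "measured", "known", "first", "only" and "open" are said of these compounds alone.

Measured compounds:
- compound 1, `CN1C[C@@H](c2ccco2)[C@@]2(Cc3ccccc3C2=O)[C@@]12C(=O)Nc1ccccc12`, 38.8%
- compound 2, `COc1ccc([C@@H]2CN(C)[C@]3(C(=O)N(C)c4ccccc43)[C@]23Cc2ccccc2C3=O)cc1`, 3.3%

In a functional assay on the whole organism (strain Wister albino) for inhibition, with Rattus norvegicus as the target, read by paw edema, with stated times of 1 h and 3 h, at a dose of 50 mg/kg by the intraperitoneal route (on this read-out higher numbers stand for more inhibition at the one dose given (going by the name of the read-out) and lower numbers for less inhibition), compound 2 gives the lower of the two numbers; compound 1 gives a number higher by a margin beyond the usual scatter. Among the measured compounds shown here, compound 1 and compound 2 differ in more than one place, so the two values show only that the pair spans a wide gap and do not isolate any single change.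

Compound 3, `COc1ccc([C@@H]2CN(C)[C@]3(C(=O)Nc4ccccc43)[C@]23Cc2ccccc2C3=O)cc1`, is not yet measured. Compared with compound 2 the change is hydrogen in place of methyl on an amide-type nitrogen in a ring. Compound 1, the higher of the measured pair, also carries hydrogen at that position, but its other differences from compound 2 prevent this from being read as a clean step. A moderate rise in this assay is expected, though with wide uncertainty. The estimated step of a number 14.7 percentage points higher from compound 2 to compound 3 (beyond the scatter) lies beyond the scatter. For compound 3 the expected value is 18%, with a range from 3% to 38%.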

Compound 3, a percentage reported as inhibition, in the whole organism at one dose (the size of the read-out at that dose, not a potency): 20.5%
For compound 3 the middle estimate is 2.5 percentage points below the measured one; measured number inside the range.
By their numbers in this assay, from the lowest: compound 2; then compound 3; then compound 1.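

In this assay, among the compounds shown here, hydrogen in place of methyl on the amide-type nitrogen in a ring gives a number 17.2 percentage points higher from compound 2 to compound 3 (beyond the scatter) and so supplies the first clean reading at this position, with 4-methoxyphenyl held fixed. With hydrogen on that nitrogen, 4-methoxyphenyl in place of furan-2-yl on a saturated ring carbon gives a number 18.3 percentage points lower from compound 1 to compound 3 (beyond the scatter) and so shows that the second place also matters, with a modest step of its own. No measurement at hand accounts for either step.

Open, going by these compounds, is whether the step from methyl to hydrogen holds with furan-2-yl on the saturated ring carbon. Also open, on these data alone, is how an acetyl group or a longer chain on the nitrogen, or a 4-chlorophenyl or pyridyl group on that carbon, would read.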